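The source may hold more compounds than are shown below. What is called first, only, known or untested is meant among the compounds shown, and "the series" means these compounds.

Of the compounds shown here, three sharing one core have been tested in a toxicity assay on MCF-10A cells (Homo sapiens) for cytotoxicity, read by MTT assay, with a stated time of 48 h; on this read-out higher numbers stand for weaker inhibition and lower numbers for stronger inhibition. Compound 1 `O=C(/C=C/c1ccc2c(c1)B(O)OC2)c1ccco1` gives 7400 nM, compound 2 `O=C(/C=C/c1ccc2c(c1)B(O)OC2)c1cccnc1` gives 34400 nM, and compound 3 `O=C(/C=C/c1ccc2c(c1)B(O)OC2)c1ccc(F)cc1` gives 11800 nM, which places compound 3 second highest of the three: the step of a 1.6-fold higher number from compound 1 to compound 3 (0.20 log units; within the scatter) stays within the scatter, whereas a 2.9-fold lower number from compound 2 to compound 3 (0.46 log units; beyond the scatter) lies beyond it. Compound 4 `CCc1ccc(C(=O)/C=C/c2ccc3c(c2)B(O)OC3)cc1` differs from compound 3 by ethyl in place of fluoro on an aromatic carbon, sitting on an aromatic carbon of a six-membered aromatic ring of carbon only, para to a large group. Every measured step swaps the whole ring on the carbonyl carbon, so none matches this change directly; the closest in spirit, a 1.6-fold higher number from compound 1 to compound 3 (0.20 log units; within the scatter), was within the scatter. The step to compound 4 is therefore expected to be small, a 1.1-fold higher number from compound 3 to compound 4 (0.04 log units; within the scatter). Compound 4 is estimated at 13000 nM, with a range from 5000 nM to 35000 nM.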

Compound 4, half-maximal inhibitory concentration: 8800 nM
The estimate for compound 4 lay 1.5-fold (0.17 log units) above the measured number, and the stated range covers the measured number.
By their numbers in this assay, from the lowest: compounds 1, 4 and 3 (each within the scatter of the next); then compound 2.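

Unlike the earlier steps, which swap the whole ring on the carbonyl carbon, this one keeps the ring and changes only the group on an aromatic carbon, para to a large group. In this assay, ethyl in place of fluoro gives a 1.3-fold lower number from compound 3 to compound 4 (0.13 log units; within the scatter) and so shows that this exchange of groups, at this place, has no effect that stands clear of the scatter. No measurement at hand offers an explanation for this result. On these data alone, whether an amine, a carboxylic acid or a longer chain at this place would also stay within the scatter remains open.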